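This account rests on a few compounds, and the source may have more. Where it says the series, first, only, none or still open, it means among the compounds named here.

Compounds in hand:
compound 1 `CC(C)[C@H](NC(=O)COc1cccc2ccccc12)C(=O)N[C@@H](CC(=O)O)C(=O)COc1ccc(C(F)(F)F)cc1`, in a functional assay on Jurkat cells (Homo sapiens) (a higher number here means a weaker inhibitor, a lower number a stronger inhibitor), compound 1 gives > 100000 nM, a limit of the assay only.
compound 2 `CC(C)[C@H](NC(=O)COc1cccc2ccccc12)C(=O)N[C@@H](CC(=O)O)C(=O)COc1ccc(C(N)=O)cc1`, compound 2 gives > 100000 nM, a limit only.
compound 3 `CC(C)[C@H](NC(=O)COc1cccc2ccccc12)C(=O)N[C@@H](CC(=O)O)C(=O)COc1ccccc1[N+](=O)[O-]`, compound 3 gives > 100000 nM, a limit only.

Compound 1 stands at the limit of this assay, with no number of its own; all three values in hand share that limit (the limit of > 100000 nM in this assay, at which 3 of the 3 values shown sit). The steps within the series are therefore unreadable: from compound 1 to compound 2 a step that the two limits leave unreadable from compound 1 to compound 2, from compound 1 to compound 3 a step that the two limits leave unreadable from compound 1 to compound 3, and from compound 2 to compound 3 a step that the two limits leave unreadable from compound 2 to compound 3.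

Compound 4 `CC(C)[C@H](NC(=O)COc1cccc2ccccc12)C(=O)N[C@@H](CC(=O)O)C(=O)COc1c(F)cccc1F` is not yet measured. It differs from compound 1 by 2,6-difluorophenyl in place of 4-(trifluoromethyl)phenyl on an oxygen on a saturated carbon. For the measured compounds named here, the steps that bear on this change are those swapping the aryl group on the oxygen on a saturated carbon, from compound 1 to compound 3 and from compound 2 to compound 3, and neither gives a size. Going by the values given here, no compound has left the limit by a change at this position. For compound 4 the expectation is again the limit, with a step from compound 1 estimated as a number no higher from compound 1 to compound 4 (the limit leaves the size open). The estimate for compound 4 is 100000 nM, within 30000 nM to 300000 nM, most likely reported only as a limit.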

Compound 4, half-maximal inhibitory concentration: 2040 nM
The estimate for compound 4 lay 49-fold (1.69 log units) above the measured number, outside the stated range (below it).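

In this assay the aryl group on the oxygen on a saturated carbon proves able to bring the series off the limit: the change to 2,6-difluorophenyl gives an at least 49-fold lower number from compound 1 to compound 4 (1.69 log units; beyond the scatter), and the same group gives an at least 49-fold lower number from compound 3 to compound 4 (1.69 log units; beyond the scatter) and an at least 49-fold lower number from compound 2 to compound 4 (1.69 log units; beyond the scatter). All three steps lie beyond the usual scatter, and each is a bound rather than a full size, as its starting compound holds only a limit. With the rest of the structure unchanged, this position is therefore not silent, although most of the aryl groups shown stay at the limit: the limit of > 100000 nM in this assay, at which 3 of the 4 values shown sit.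

Going by these compounds, whether a monofluorophenyl or a dichlorophenyl group would also leave the limit remains open, so the number of fluorines and the identity of the halogen are not separated. The steps among compound 1, compound 2 and compound 3 cannot be read.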